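Amide-nitrogen ring swaps in a paw edema model

This account rests on a few compounds, and the source may have more. Where it says the series, first, only, none or still open, it means among the compounds named here.

The measured compounds:
compound 1 `O=C(Nc1ccccn1)c1c(O)c2cccnc2n(-c2ccccc2)c1=O` with 14.6%
compound 2 `Cc1ccccc1NC(=O)c1c(O)c2cccnc2n(-c2ccccc2)c1=O` with 9.8%
compound 3 `O=C(Nc1nccs1)c1c(O)c2cccnc2n(-c2ccccc2)c1=O` with 2.5%

In a functional assay on the whole organism for inhibition, with Rattus norvegicus as the target, read by cytopathic effect and paw edema, at a dose of 100 mg/kg by the oral route (a higher number here means more inhibition at the dose given (going by the name of the read-out), a lower number less inhibition), compound 3 gives the lowest of the three numbers, yet only its distance from compound 1 lies beyond the scatter, while compound 2 sits within it. The shared core is kept throughout; what changes is the ring on the amide-type nitrogen. Going to compound 4 `Cc1cnccc1NC(=O)c1c(O)c2cccnc2n(-c2ccccc2)c1=O` means (3-methylpyridin-4-yl in place of 1,3-thiazol-2-yl on an amide-type nitrogen).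

Going by the values given here, two measured steps bear on this. The step of a number 12.1 percentage points lower from compound 1 to compound 3 (beyond the scatter) sets a six-membered ring with one nitrogen against the five-membered ring, and the step of a number 7.3 percentage points lower from compound 2 to compound 3 (within the scatter) sets a methyl-bearing six-membered ring against the same five-membered ring. The entering group in compound 4 carries both features, a six-membered ring with one nitrogen and a methyl. Reversing those steps, the account expects a modest rise in this assay, of roughly the size seen between compound 1 and compound 3, though a change within the scatter cannot be excluded.

Compound 4 is therefore expected to give about 11%, within 2% to 22%. The expected step is a number 8.5 percentage points higher from compound 3 to compound 4 (within the scatter).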

Compound 4, a percentage reported as inhibition, in the whole organism at one dose (the size of the read-out at that dose, not a potency): 8.8%
Estimate against measurement, compound 4: 2.2 percentage points above; low and high end bracket the measured number.
By their numbers in this assay, from the lowest: compounds 3, 4, 2 and 1 (each within the scatter of the next, the first and the last beyond it).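

In this assay, the 3-methylpyridin-4-yl group on the amide-type nitrogen does not separate from any of the three earlier groups: the steps read a number 6.3 percentage points higher from compound 3 to compound 4 (within the scatter), a number 1 percentage points lower from compound 2 to compound 4 (within the scatter) and a number 5.8 percentage points lower from compound 1 to compound 4 (within the scatter). Going by these compounds alone, the only gap beyond the scatter therefore remains the one between compound 1 and compound 3, while compound 2 and compound 4 each lie within the scatter of every other compound, so a six-membered aromatic ring bearing both a ring nitrogen and a methyl opens no second gap at this position. No measurement offered here explains why these groups give the values they do.

The compounds shown leave open whether anything other than an aromatic ring on the amide-type nitrogen, such as a longer alkyl chain or a benzyl group, would move the number beyond the scatter in either direction. They also leave open what a carboxylic acid or an amine on the ring would do, and whether the small gap between compound 1 and compound 3 would hold up in further series built on the shared core.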